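Extending the Ester Chain by One Carbon

The source may hold more compounds than are shown below. What is called first, only, known or untested is meant among the compounds shown, and "the series" means these compounds.

Compound 1 `CCCCCCCOC(=O)CCC(=O)N1CCN(CCCOc2cc3c(Nc4ccc(F)c(Cl)c4)ncnc3cc2OC)CC1` and compound 2 `CCCCCCCCCCCCCCCOC(=O)CCC(=O)N1CCN(CCCOc2cc3c(Nc4ccc(F)c(Cl)c4)ncnc3cc2OC)CC1` share one core and differ only in the length of the ester chain. In a functional assay on A549 cells (Homo sapiens) for cytotoxicity, read by MTT assay, with a stated time of 24 h, tested at 20 uM (a lower number here means a stronger effect, a higher number a weaker effect of the compound at the concentration tested), compound 1 gives 79.9%, while compound 2 gives 91.2%. Within the data shown here, the step of a number 11.3 percentage points higher from compound 1 to compound 2 (beyond the scatter) places compound 2 as the higher of the two numbers measured so far, with compound 1 as its only neighbour. Compound 3 `CCCCCCCCCCCCCCCCOC(=O)CCC(=O)N1CCN(CCCOc2cc3c(Nc4ccc(F)c(Cl)c4)ncnc3cc2OC)CC1` carries the change (methyl in place of hydrogen on a saturated chain carbon, ten or more bonds along the chain from an oxygen next to a carbonyl group). Among the measured compounds shown here, the one measured step that bears on this change, a number 11.3 percentage points higher from compound 1 to compound 2 (beyond the scatter), was modest even though it brought in a much longer piece of chain; a single added carbon is therefore expected to shift this assay little, if at all, and not beyond the scatter. Compound 3 is expected to give 92%, between 82% and 100%. This estimate amounts to an expected step of a number 0.8 percentage points higher from compound 2 to compound 3 (within the scatter).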

Compound 3, a percentage reported as activity, at one concentration (the size of the read-out at that concentration, not a potency): 91.7%
For compound 3 the middle estimate is 0.3 percentage points above the measured one; measured number inside the range.
By their numbers in this assay, from the lowest: compound 1; then compounds 2 and 3 (each within the scatter of the next).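

In this assay the methyl, placed on a saturated chain carbon, gives a number 0.5 percentage points higher from compound 2 to compound 3 (within the scatter), so the added carbon leaves compound 2 and compound 3 indistinguishable. Set against the shorter chain, the nonyl change gives a number 11.8 percentage points higher from compound 1 to compound 3 (beyond the scatter), which means that of these three compounds only compound 1 stands apart from the others. Nothing available here explains this behaviour of the chain.

The compounds shown leave open how the read-out moves with chains of intermediate length, or with a chain shorter than that of compound 1. They also leave open what a carboxylic acid or an amine in place of the long chain would give.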